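Compound 3 to compound 4: replacing pyrrolidin-1-yl

The compounds below may be only part of what the source reports. "The series", "measured", "known", "first", "only" and "open" are said of these compounds alone.

In a functional assay on MGC-803 cells (Homo sapiens) for inhibition, read by sulforhodamine B assay (a higher number here means a weaker inhibitor, a lower number a stronger inhibitor), compound 3 `O=C1C(N2CCCC2)=CC(=O)c2c1nc1n2[C@H]2OC[C@@H](O)[C@H]2OC1` gives > 16000 nM, which is a limit and not a number. Compound 1 `O=C1C(Nc2ccccc2)=CC(=O)c2c1nc1n2[C@H]2OC[C@@H](O)[C@H]2OC1` gives 1830 nM and compound 2 `O=C1C(Nc2ccc(Br)cc2)=CC(=O)c2c1nc1n2[C@H]2OC[C@@H](O)[C@H]2OC1` gives 2020 nM. Compound 4 `COc1ccc(NC2=CC(=O)c3c(nc4n3[C@H]3OC[C@@H](O)[C@H]3OC4)C2=O)cc1` carries (4-methoxyphenyl)amino in place of pyrrolidin-1-yl on a double-bonded ring carbon. The opposite kind of exchange has been measured twice, an at least 8.7-fold higher number from compound 1 to compound 3 (0.94 log units; beyond the scatter) and an at least 7.9-fold higher number from compound 2 to compound 3 (0.89 log units; beyond the scatter), both beyond the scatter. The substituent on the aromatic ring mattered little in the one case measured, a 1.1-fold higher number from compound 1 to compound 2 (0.04 log units; within the scatter). A step toward a lower number is therefore expected in this assay, estimated as an at least 8.0-fold lower number from compound 3 to compound 4 (0.90 log units; beyond the scatter). Compound 4 is expected at 2000 nM, with an estimated range of 900 nM to 5000 nM.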

Compound 4, half-maximal inhibitory concentration: 2150 nM
The estimate for compound 4 lay 1.1-fold (0.03 log units) below the measured number; the range from low to high includes it.
By their numbers in this assay, from the lowest: compounds 1, 2 and 4 (each within the scatter of the next). At a limit, above all of these: compound 3.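

In this assay, the exchange at this double-bonded ring carbon also reads in the forward direction, an at least 7.4-fold lower number from compound 3 to compound 4 (0.87 log units; beyond the scatter), so the gap between pyrrolidin-1-yl and the arylamino groups holds for a third aromatic partner. Methoxy adds no readable change on the aromatic ring, with a 1.2-fold higher number from compound 1 to compound 4 (0.07 log units; within the scatter) and a 1.1-fold higher number from compound 2 to compound 4 (0.03 log units; within the scatter), which leaves hydrogen, bromo and methoxy within the scatter of each other. The step from compound 3 has an open end, since compound 3 stands at a limit: the limit of > 16000 nM in this assay, at which 1 of the 4 values shown sits.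

Still open, going by these compounds, is whether the gap follows the aromatic ring or the hydrogen-bond donor. Cyclopentylamino and methyl(phenyl)amino at this carbon would separate the two.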